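Swapping Nitro for Sulfamoyl on a Shared Core

This account rests on a few compounds, and the source may have more. Where it says the series, first, only, none or still open, it means among the compounds named here.

Measured so far:
compound 1 `O=c1c2c(Nc3ccccc3)nn(-c3ccccc3)c2nc(Nc2ccccc2)n1-c1ccccc1` gives 17.1%
compound 2 `O=c1c2c(Nc3ccccc3)nn(-c3ccc([N+](=O)[O-])cc3)c2nc(Nc2ccccc2)n1-c1ccccc1` gives 14.1%

Both numbers come from a functional assay on the whole organism (strain Wistar albino) for inhibition, with Rattus norvegicus as the target, read by paw edema, with a stated time of 3 h, at a dose of 25 mg/kg by the oral route; a higher number here means more inhibition at the dose given (going by the name of the read-out), a lower number less inhibition. Among the compounds with values here, compound 2 stands at the lower of the two values, with compound 1 the only neighbour, but the step of a number 3 percentage points lower from compound 1 to compound 2 (within the scatter) lies within the scatter, so the two compounds cannot be told apart on these numbers.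

Compound 3 `NS(=O)(=O)c1ccc(-n2nc(Nc3ccccc3)c3c(=O)n(-c4ccccc4)c(Nc4ccccc4)nc32)cc1` has not been measured. It differs from compound 2 in a single place: sulfamoyl in place of nitro on an aromatic carbon. Within the data shown here, only one measured step exists, a number 3 percentage points lower from compound 1 to compound 2 (within the scatter), and it concerns a nitro entering for hydrogen, not the exchange of nitro for sulfamoyl, so it bears on the new change only loosely; it showed no movement beyond the scatter.

On that basis, the step of a number 0.9 percentage points higher from compound 2 to compound 3 (within the scatter) is expected to stay within the scatter. Compound 3 is therefore estimated at 15%, with a likely range from 5% to 28%.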

Compound 3, a percentage reported as inhibition, in the whole organism at one dose (the size of the read-out at that dose, not a potency): 39.7%
Estimate against measurement, compound 3: 24.7 percentage points below; the whole stated range lies below it.
By their numbers in this assay, from the lowest: compounds 2 and 1 (each within the scatter of the next); then compound 3.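

The earlier compounds shown here gave no sign that this position matters, since nitro in place of hydrogen produced no readable change. In this assay, sulfamoyl changes that picture, with a number 25.6 percentage points higher from compound 2 to compound 3 (beyond the scatter) and a number 22.6 percentage points higher from compound 1 to compound 3 (beyond the scatter), so what sits on this aromatic carbon can move the read-out, and the identity of the group counts, not just the replacement of hydrogen. Sulfamoyl brings a hydrogen-bond donor that nitro lacks, but no available measurement links the rise to that difference or to any other cause.

From the compounds shown here alone, whether a carboxylic acid or a methylsulfonyl group in the same place would also raise the number remains open, as does whether sulfamoyl carrying a methyl on its nitrogen would keep the gain. Going by these compounds, these values also come from a single dose and a single time, so how the inhibition varies with dose is unknown.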